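The source may report more compounds than this note shows. Statements on the series, on what has been measured and on what is new or still open speak of the compounds shown alone.

Compound 1 `O=C(O)c1cc(-c2cccc(COc3ccc4c(=O)n(CC5CC5)sc4c3)c2)ccc1Cl`: 100%
Compound 2 `O=C(O)c1cc(-c2cccc(COc3ccc4c(=O)n(C5CCCC5)sc4c3)c2)ccc1F`: 100%

Among the compounds with values here, in an ADME assay on a cell-free system (plasma, Rattus norvegicus) for metabolic stability, read by LC-MS, with a stated time of 1 h, at 37 degrees C, tested at 100 uM (on this read-out higher numbers stand for a more stable compound and lower numbers for a less stable compound), compound 2 stands at 100%, level with compound 1 at 100%, and nothing measured so far falls short of that figure. The next compound, compound 3 `Cc1ccc(C(=O)O)cc1-c1cccc(COc2ccc3c(=O)n(C4CCCC4)sc3c2)c1`, keeps the shared core and the cyclopentyl group of compound 2. The change is on an aromatic carbon, where 5-carboxy-2-methylphenyl takes the place of 3-carboxy-4-fluorophenyl: 5-carboxy-2-methylphenyl in place of 3-carboxy-4-fluorophenyl on an aromatic carbon. Within the data shown here, no measured pair differs in one place only, so the data give no direct measure of such a swap. With compound 2 at 100%, no change beyond the scatter is expected in this assay, and any real shift could only be downward. The expected step is a number 3 percentage points lower from compound 2 to compound 3 (within the scatter). For compound 3 the estimate is 97%, with an expected range of 85% to 105%.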

Compound 3, percent of the compound remaining: 100%
The estimate for compound 3 lay 3 percentage points below the measured number, within the range that was stated.
By their numbers in this assay, from the lowest: compounds 1, 2 and 3 (each within the scatter of the next).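

In this assay, within the data shown here, the exchange of 3-carboxy-4-fluorophenyl for 5-carboxy-2-methylphenyl, on an aromatic carbon meta to a large group, gives a result of no change at the digits printed from compound 2 to compound 3 (within the scatter) and so supplies the first pair here that differs in one place only. It shows that this position accepts a methyl group on the ring in place of the fluorine, along with the other placement of the carboxy group named in 5-carboxy-2-methylphenyl, with no loss this read-out can register. Nothing in the data explains why the figure holds.

All three compounds stand at the same printed figure, so the read-out has not yet separated any of them at this position. As far as these compounds go, it remains open whether an amine or a methyl ester in place of the carboxylic acid, or a longer chain in place of the cyclopentyl group, would hold that figure.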